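Amino for dimethylamino on the amide chain

The source may report more compounds than this note shows. Statements on the series, on what has been measured and on what is new or still open speak of the compounds shown alone.

Compound 2 `COc1ccc(C(=O)c2ccc3c(c2)C=CC(C)(C)O3)c(NC(=O)CN(C)C)c1` and compound 1 `COc1ccc(C(=O)c2ccc3c(c2)C=CC(C)(C)O3)c(NC(=O)CN)c1` share one core; compound 3 `COc1ccc(C(=O)c2cc(OC)c(OC)c(OC)c2)c(NC(=O)CN(C)C)c1` and compound 4 `COc1ccc(C(=O)c2cc(OC)c(OC)c(OC)c2)c(NC(=O)CN)c1` share another, and the difference between the two cores is not broken down here. In a functional assay on HeLa cells (Homo sapiens) for antiproliferative activity, read by MTT assay, with a stated time of 48 h (on this read-out lower numbers stand for stronger inhibition and higher numbers for weaker inhibition), compound 2 gives 1260 nM and compound 1 gives 580 nM. The change between them is amino in place of dimethylamino on a saturated chain carbon bound to a carbonyl carbon, and in this assay it produced a 2.2-fold lower number from compound 2 to compound 1 (0.34 log units; beyond the scatter). Compound 3 gives 470 nM in this assay, within the scatter of compound 1. Compound 4 carries the same change on the other core: amino in place of dimethylamino on a saturated chain carbon bound to a carbonyl carbon. Among the compounds with values here, a step of about a 2.1-fold lower number from compound 3 to compound 4 (0.33 log units; beyond the scatter) is expected in this assay, resting on the single measured instance of this change, a 2.2-fold lower number from compound 2 to compound 1 (0.34 log units; beyond the scatter). Compound 4 is therefore estimated at 220 nM in this assay. Within the data shown here, only one pair supports the transfer, so the expected range for compound 4 runs from 100 nM to 480 nM.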

Compound 4, half-maximal inhibitory concentration: 130 nM
The estimate for compound 4 lay 1.7-fold (0.23 log units) above the measured number; low and high end bracket the measured number.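

In this assay, the change carried to the second core gives a 3.6-fold lower number from compound 3 to compound 4 (0.56 log units; beyond the scatter), in the same direction as on the first core. Set side by side, the two steps do not differ: the same change on two cores in this assay, a 2.2-fold lower number (0.34 log units; beyond the scatter) from compound 2 to compound 1 and a 3.6-fold lower number (0.56 log units; beyond the scatter) from compound 3 to compound 4, 1.7-fold (0.22 log units) apart, within the scatter of two such steps Amino in place of dimethylamino therefore carries over in direction and, within the scatter, in size on these two cores, but two pairs do not show that it would hold on any other core.

Open, on these data alone, is how methylamino, with a single methyl group kept on the nitrogen, would compare with amino and dimethylamino on either core. Also open, as far as these compounds go, is how a longer chain carrying the amino group, or a cyclic amine such as pyrrolidine, would read.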